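A few compounds are considered here, and "the series" means these few. Any claim that something is new, unique, unknown or untested is made for them only; others in the source may bear on it.

In a physicochemical assay for lipophilicity, using the shake flask method, measured as octanol-water partition, at pH 7.4 (a higher number here means a more lipophilic compound, a lower number a more polar compound), compound 1 `NC(=O)c1cnc2ccc(-c3cccnc3)cc2c1NC1CCCCC1` gives 3.8 as a measured number. Compound 2 `NC(=O)c1cnc2ccc(-c3cccnc3)cc2c1NCC1CCCCC1` stands at > 4.3 which is a limit of the assay and not a number. Within the data shown here, the one measured step is a number at least 0.50 log units higher from compound 1 to compound 2 (beyond the scatter) for cyclohexylmethyl in place of cyclohexyl on a nitrogen on an aromatic ring. Compound 3 `C[C@H](Nc1c(C(N)=O)cnc2ccc(-c3cccnc3)cc12)C1CCOCC1` carries 1-(oxan-4-yl)ethyl in place of cyclohexylmethyl at that same nitrogen, a change counted as 1-(oxan-4-yl)ethyl in place of cyclohexylmethyl on a nitrogen on an aromatic ring in full. The measured step involves rings of carbon only, so it gives no direct size for the entry of a ring with a hetero atom. A downward step beyond the scatter is still expected in this assay. The nearest measured reference is compound 1 at 3.8 for comparison. The expected change is a number at least 1.10 log units lower from compound 2 to compound 3 (beyond the scatter) and it is reckoned from a limit. Compound 3 is estimated at 3.2 with an expected range from 2.7 to 3.7 as the working figure.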

Compound 3, distribution coefficient: 2.5
The estimate for compound 3 lay 0.70 log units above the measured number; the whole stated range lies above it.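

In this assay, 1-(oxan-4-yl)ethyl in place of cyclohexylmethyl on a nitrogen on an aromatic ring gives a number at least 1.80 log units lower from compound 2 to compound 3 (beyond the scatter). Going by these compounds, the start of that step is a limit of the assay and not a number, so its full size stays unknown, and compound 2 holds that limit: the limit of > 4.3 in this assay, at which 1 of the 3 values shown sits. Measured values at both ends are available for 1-(oxan-4-yl)ethyl in place of cyclohexyl, which gives a number 1.30 log units lower from compound 1 to compound 3 (beyond the scatter), so across the three compounds the group at this nitrogen moves the read-out both upward and downward.

This change brings in a ring with a hetero atom and a defined stereocentre together, and the compounds shown do not separate the two. On these data alone, how oxan-4-ylmethyl, or a six-membered ring carrying an amine, would read at this nitrogen remains open.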